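Where the Methoxy Sits: From Compound 3 to Compound 4

A few compounds are considered here, and "the series" means these few. Any claim that something is new, unique, unknown or untested is made for them only; others in the source may bear on it.

Compound 1 `Brc1cn2ccnc2c(-c2ccc3ncn(C4CCCCC4)c3c2)n1` gives 10.2% in a functional assay on SK-MEL-2 cells (Homo sapiens) for inhibition, read by sulforhodamine B assay, with a stated time of 48 h, tested at 10 uM; on this read-out higher numbers stand for more inhibition at the one concentration tested (going by the name of the read-out) and lower numbers for less inhibition.
Compound 2 `COc1ccc(-c2cn3ccnc3c(-c3ccc4ncn(C5CCCCC5)c4c3)n2)cc1` gives 94.3% in this assay.
Compound 3 `CC(=O)c1ccc(-c2cn3ccnc3c(-c3ccc4ncn(C5CCCCC5)c4c3)n2)cc1` gives 0.58% in this assay.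

On the numbers shown, compound 3 sits alongside one neighbour and far from the other: a number 9.6 percentage points lower from compound 1 to compound 3 (within the scatter), but a number 93.7 percentage points lower from compound 2 to compound 3 (beyond the scatter). Compound 4 `COc1ccccc1-c1cn2ccnc2c(-c2ccc3ncn(C4CCCCC4)c3c2)n1` arises from compound 3 by 2-methoxyphenyl in place of 4-acetylphenyl on an aromatic carbon.

Among the measured compounds shown here, two measured steps bear on this change. Swapping methoxy for acetyl on the phenyl ring produced a large fall, a number 93.7 percentage points lower from compound 2 to compound 3 (beyond the scatter), so restoring a methoxy reverses the group that accompanied that fall. Putting a methoxyphenyl in place of bromo produced a large rise, a number 84.1 percentage points higher from compound 1 to compound 2 (beyond the scatter). Both steps point upward. For the measured compounds named here, the methoxy, however, now enters as 2-methoxyphenyl rather than 4-methoxyphenyl, and no measured compound shows how much of the rise depends on that placement, so the range must stay wide.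

Compound 4 is therefore expected to show a large step upward in this assay, namely a number 59.4 percentage points higher from compound 3 to compound 4 (beyond the scatter). The estimate for compound 4 is 60%, with a range from 15% to 95%.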

Compound 4, a percentage reported as inhibition, at one concentration (the size of the read-out at that concentration, not a potency): 12.1%
For compound 4 the middle estimate is 47.9 percentage points above the measured one, and the stated range ends above it.
By their numbers in this assay, from the lowest: compounds 3, 1 and 4 (each within the scatter of the next, the first and the last beyond it); then compound 2.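

Moving the methoxy around the phenyl ring is the change the earlier compounds could not isolate, and in this assay it matters greatly: a number 82.2 percentage points lower from compound 2 to compound 4 (beyond the scatter), so the high inhibition belongs to the 4-methoxyphenyl group, not to any methoxyphenyl at this aromatic carbon. The 2-methoxyphenyl group offers little gain over the other groups, with a number 11.5 percentage points higher from compound 3 to compound 4 (beyond the scatter) and a number 1.9 percentage points higher from compound 1 to compound 4 (within the scatter), leaving the 4-methoxyphenyl group alone in standing out among the four. Nothing available explains this dependence on placement.

As far as these compounds go, it remains open how a plain phenyl ring would read at this carbon, and whether an amine or an ethoxy group could replace the methoxy of the 4-methoxyphenyl group and keep the high inhibition. Readings at one concentration also leave the potency of these compounds unknown.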